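Swapping a Carbamoyl for a Methyl on the Aryl Ring

The source may report more compounds than this note shows. Statements on the series, on what has been measured and on what is new or still open speak of the compounds shown alone.

Measured compounds:
- compound 1, `CNC(=O)c1ccc(-c2cc(C(=O)N[C@H]3CCCNC3)c(NC(N)=O)s2)cc1`, in an assay on isolated protein for inhibition of cyclin-dependent kinase 2-associated protein 1 (Homo sapiens); a higher number here means a weaker inhibitor, a lower number a stronger inhibitor: "not determined" (no result reported)
- compound 2, `CN(C)C(=O)c1ccc(-c2cc(C(=O)N[C@H]3CCCNC3)c(NC(N)=O)s2)cc1`, in this assay: 3700 nM
- compound 3, `NC(=O)Nc1sc(-c2ccc(C(N)=O)cc2)cc1C(=O)N[C@H]1CCCNC1`, in this assay: "not determined" (no result reported)

All three share the same core and differ only in the group at the far end of the six-membered aromatic ring. Only compound 2 carries a number in this assay; for compound 1 and compound 3 no result was reported, so compound 3 has no position among the values, and nothing can be said about how its carbamoyl compares with the dimethylcarbamoyl of compound 2.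

Compound 4, `Cc1ccc(-c2cc(C(=O)N[C@H]3CCCNC3)c(NC(N)=O)s2)cc1`, differs from compound 3 by methyl in place of carbamoyl on an aromatic carbon. For the measured compounds named here, no measured pair shows the effect of such a change, so the direction of the step is open: it could weaken binding, strengthen it, or stay within the scatter. With compound 2 as the only anchor, compound 4 is expected to give roughly 5000 nM in this assay, with a wide range from 1000 nM to 25000 nM.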

Compound 4, half-maximal inhibitory concentration: 5500 nM
Compound 4: middle estimate off by 1.1-fold (0.04 log units), on the low side; the range from low to high includes it.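

Replacing dimethylcarbamoyl with methyl on the aromatic ring gives a 1.5-fold higher number from compound 2 to compound 4 (0.17 log units; within the scatter) in this assay. For the compounds shown here, this is the first readable comparison at this position, and it shows that a small methyl and a much larger dimethylcarbamoyl group cannot be told apart here, even though the two groups differ clearly in size and atoms. The data shown offer no explanation for this result.

On these data alone, the steps involving compound 1 and compound 3 cannot be read, so how the methylcarbamoyl and carbamoyl groups compare with methyl or dimethylcarbamoyl remains open. Also open, as far as these compounds go, is whether an amine, a carboxylic acid or a longer carbon chain at this position would move the value in this assay beyond the usual scatter.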